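Swapping a furan for an aminophenyl on a boron-bearing chalcone

The source may report more compounds than this note shows. Statements on the series, on what has been measured and on what is new or still open speak of the compounds shown alone.

The compounds here share a carbonyl linked through a double-bonded chain to an aromatic ring, and they were tested in an ADME assay on L929 cells (Mus musculus) for cytotoxicity, read by resazurin assay, with a stated time of 72 h; a lower number here means a stronger inhibitor, a higher number a weaker inhibitor. Compound 1 `O=C(/C=C/c1ccc2c(c1)B(O)OC2)c1ccco1` gives only a limit in this assay, > 10 ug/mL. Compound 3 `O=C(/C=C/c1ccc2c(c1)B(O)OC2)c1ccc(Cl)c(Cl)c1` likewise reaches only the limit, > 10 ug/mL. Compound 2 `COc1cccc(C(=O)/C=C/c2ccccc2)c1`, which lacks the boron-containing ring, gives a measured value of 5.7 ug/mL in this assay. Compound 1 therefore stands at the weak end of what is shown, sitting at the limit of > 10 ug/mL in this assay, at which 2 of the 3 values shown sit.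

The new compound 4 `Nc1ccc(C(=O)/C=C/c2ccc3c(c2)B(O)OC3)cc1` differs from compound 1 in one place: 4-aminophenyl in place of furan-2-yl on a carbonyl carbon. Among the measured compounds shown here, no pair of measured compounds shows the effect of this particular change, so the size of the step has to be guessed from the whole set. Both boron-containing compounds sit at the limit, so the expectation is that compound 4 stays in that same weak region, with a step from compound 1 of a step that the limit leaves unreadable from compound 1 to compound 4 that is expected to lie within the scatter. Compound 4 is thus estimated at 15 ug/mL, with a range from 6 ug/mL to 40 ug/mL.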

Compound 4, half-maximal inhibitory concentration: > 10 ug/mL
Compound 4 was reported as a limit; the forecaster's own chance of this, stated with the estimate: 65%; the middle value lies beyond the limit too.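

Compound 1 and compound 4 each give only a limit in this assay, so the size of the swap from furan-2-yl to 4-aminophenyl cannot be read: the limit of > 10 ug/mL in this assay, at which 3 of the 4 values shown sit.

The compounds shown leave open whether these two groups differ at all in this cell assay.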